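Methyl to methoxy on the pendant aryl ring: two placements

A few compounds are considered here, and "the series" means these few. Any claim that something is new, unique, unknown or untested is made for them only; others in the source may bear on it.

Measured compounds:
compound 1 `Cc1ccc(-c2nc(C(F)(F)F)n(CC[C@@H](O)C[C@@H](O)CC(=O)O)c2-c2ccc(F)cc2)cc1` 43 nM
compound 2 `COc1ccc(-c2nc(C(F)(F)F)n(CC[C@@H](O)C[C@@H](O)CC(=O)O)c2-c2ccc(F)cc2)cc1` 68 nM
compound 3 `Cc1cccc(-c2c(-c3ccc(F)cc3)nc(C(F)(F)F)n2CC[C@@H](O)C[C@@H](O)CC(=O)O)c1` 74 nM

All three were run in an assay on microsomes from liver for inhibition of 3-hydroxy-3-methylglutaryl-coenzyme A reductase (Rattus norvegicus); on this read-out higher numbers stand for weaker inhibition and lower numbers for stronger inhibition. Compound 1 and compound 3 have the same atoms joined differently; the difference between the two cores is not broken down here. Compound 3 stands at the highest of the three numbers, but its distance to compound 2 and to compound 1 is within the scatter, so no order among the three is claimed.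

One structural change is measured once. From compound 1 to compound 2 the change is methoxy in place of methyl on an aromatic carbon, giving a 1.6-fold higher number from compound 1 to compound 2 (0.20 log units; within the scatter). The same kind of change is to be made from compound 3 to compound 4 `COc1cccc(-c2c(-c3ccc(F)cc3)nc(C(F)(F)F)n2CC[C@@H](O)C[C@@H](O)CC(=O)O)c1`, which is methoxy in place of methyl on an aromatic carbon. The surroundings are not identical: in compound 1 the methyl sits para to a large group, in compound 3 meta to a large group, so this is the same kind of change rather than the same change.

Given that the measured step is within the scatter, the expectation for compound 4 rests on the same change repeating roughly as before; the estimated step is a 1.5-fold higher number from compound 3 to compound 4 (0.17 log units; within the scatter). The expected value for compound 4 in this assay is 110 nM, with an estimated range from 55 nM to 220 nM, because compound 3 gives 74 nM and the only measured methyl to methoxy step is a 1.6-fold higher number from compound 1 to compound 2 (0.20 log units; within the scatter).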

Compound 4, half-maximal inhibitory concentration: 135 nM
Beside the measured number, compound 4's estimate is 1.2-fold (0.09 log units) below it; the range from low to high includes it.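

In this assay, methoxy in place of methyl on an aromatic carbon, here 3-methylphenyl to 3-methoxyphenyl, gives a 1.8-fold higher number from compound 3 to compound 4 (0.26 log units; within the scatter). Set beside the earlier case, the step on the second core does not differ from the step on the first: the same change on two cores in this assay, a 1.6-fold higher number (0.20 log units; within the scatter) from compound 1 to compound 2 and a 1.8-fold higher number (0.26 log units; within the scatter) from compound 3 to compound 4, 1.2-fold (0.06 log units) apart, within the scatter of two such steps. This shows that the two pairs give no sign of the change reading differently on these two cores, although the group sits para to a large group in one pair and meta to a large group in the other; it does not show that the change has a real effect on this read-out, since each step lies within the scatter on its own, and two pairs do not establish that it would carry to a further core.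

Still open, going by these compounds, is whether a group of another kind at these places, such as an ethoxy chain, a hydroxyl, an amine or a nitrile, would give a step beyond the scatter on either core. Also open, on these data alone, is whether the agreement between the cores would hold for such groups, as the two pairs cover only the replacement of methyl by methoxy.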